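The compounds below may be only part of what the source reports. "The series", "measured", "known", "first", "only" and "open" are said of these compounds alone.

Measured compounds:
Compound 1, `N=C(NCCC(O)c1ccccc1N)c1ccccc1`, gives 64.1% in an assay for inhibition of Nitric oxide synthase, inducible (Homo sapiens), with a stated time of 30 min, tested at 1 mM; a higher number here means more inhibition at the concentration tested (going by the name of the read-out), a lower number less inhibition.
Compound 2, `N=C(NCCC(O)c1ccccc1N)c1ccc(Cl)cc1`, gives 73.2% in this assay.
Compound 3, `CC(=N)NCCC(=O)c1ccccc1N`, gives 22.3% in this assay.

Compound 1 and compound 2 differ in one place: chloro in place of hydrogen on an aromatic carbon. This change made a step of a number 9.1 percentage points higher from compound 1 to compound 2 (within the scatter), so the two numbers are not told apart by this assay. Compound 3 is built on a different core, and the difference between the two cores is not broken down here; what is seen is that compound 3 stands lowest of the three, with compound 1 the nearest of the two above it and compound 2 the furthest, both beyond the scatter.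

Compound 4, `CC(=N)NCCC(=O)c1cc(Cl)ccc1N`, has not yet been measured in this assay. It differs from compound 3 by chloro in place of hydrogen on an aromatic carbon. Going by the values given here, this is the same kind of change as the one from compound 1 to compound 2, though not the same: in compound 2 the chloro stands para to a large group, whereas in compound 4 it stands meta to a group of 8 heavy atoms and para to an amino group, on the core of compound 3 rather than that of compound 1.

Among the compounds with values here, the only guide is the step seen between compound 1 and compound 2, which was within the scatter, so from compound 3 to compound 4 a step of a number 5.7 percentage points higher from compound 3 to compound 4 (within the scatter) is expected, because a number 9.1 percentage points higher from compound 1 to compound 2 (within the scatter) gave no clear gain. Compound 4 is therefore expected to give about 28%, estimated to fall between 12% and 46%.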

Compound 4, a percentage reported as inhibition, at one concentration (the size of the read-out at that concentration, not a potency): 99.1%
Estimate against measurement, compound 4: 71.1 percentage points below; measured number above the stated range.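

In this assay, chloro in place of hydrogen on an aromatic carbon gave a large step on the core of compound 3, a number 76.8 percentage points higher from compound 3 to compound 4 (beyond the scatter). The same kind of change did not give a step of the same size on the core of compound 1, so in this series its size did not carry from one core to the other: the same change on two cores in this assay, a number 9.1 percentage points higher (within the scatter) from compound 1 to compound 2 and a number 76.8 percentage points higher (beyond the scatter) from compound 3 to compound 4, 67.7 percentage points apart, beyond the scatter of two such steps

This shows that a step seen on one core was a poor guide to the step on the other, but it rests on a single pair for each core, and it does not show which difference between the cores or which difference in the place of the chloro lies behind the gap, nor does a percentage read at one concentration give a potency.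

The compounds shown leave open whether fluoro, bromo or methyl in that same place on the core of compound 3 would give a step of similar size, and whether a chloro on another carbon of that ring would do so. They also leave open whether the step would hold on a core carrying a hydroxyl group in place of the carbonyl with the methyl group kept, or a longer chain.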